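The source may hold more compounds than are shown below. What is called first, only, known or untested is meant among the compounds shown, and "the series" means these compounds.

Compounds measured so far in a functional assay on HL-60 cells (Homo sapiens) for cytotoxicity, read by MTT assay, with a stated time of 48 h (on this read-out lower numbers stand for stronger inhibition and higher numbers for weaker inhibition), are:
compound 1 `[O-][n+]1nc(NCc2ccccc2)[n+]([O-])c2ccccc21` at 2500 nM
compound 2 `CCNc1n[n+]([O-])c2ccccc2[n+]1[O-]` at 9000 nM
compound 3 `CCCCCCCCNc1n[n+]([O-])c2ccccc2[n+]1[O-]` at 7200 nM

Compound 3 sits with compound 2 and apart from compound 1. The step of a 1.3-fold lower number from compound 2 to compound 3 (0.10 log units; within the scatter) stays within the scatter, whereas the step of a 2.9-fold higher number from compound 1 to compound 3 (0.46 log units; beyond the scatter) goes beyond it. Compound 4 `C=CCNc1n[n+]([O-])c2ccccc2[n+]1[O-]` has vinyl in place of heptyl on a saturated chain carbon bound to a nitrogen on an aromatic ring. The modest steps of a 3.6-fold higher number from compound 1 to compound 2 (0.56 log units; beyond the scatter) and a 2.9-fold higher number from compound 1 to compound 3 (0.46 log units; beyond the scatter) both remove phenyl, and compound 4 carries none at that place either. No step beyond the scatter is therefore expected in this assay, the expected change being a 1.0-fold lower number from compound 3 to compound 4 (0.01 log units; within the scatter) in this estimate. Compound 4 is expected at 7000 nM with an estimated range from 3000 nM to 14000 nM for the coming measurement.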

Compound 4, half-maximal inhibitory concentration: 25800 nM
Compound 4: the middle estimate sits 3.7-fold (0.57 log units) below what was measured; the whole stated range lies below it.
By their numbers in this assay, from the lowest: compound 1; then compounds 3 and 2 (each within the scatter of the next); then compound 4.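

In this assay the group at this place moves the number even when no phenyl is involved, since a 3.6-fold higher number from compound 3 to compound 4 (0.55 log units; beyond the scatter) and a 2.9-fold higher number from compound 2 to compound 4 (0.46 log units; beyond the scatter) both lie beyond the scatter, although methyl and heptyl stay within it of each other. The largest gap among the four is a 10-fold higher number from compound 1 to compound 4 (1.01 log units; beyond the scatter) and it separates vinyl from phenyl. Nothing given here accounts for vinyl parting from the saturated groups. The compounds shown leave open whether a propyl group, with the same chain but no double bond, would sit with compound 2 and compound 3 or with compound 4.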